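The source may report more compounds than this note shows. Statements on the series, on what has been measured and on what is new or still open speak of the compounds shown alone.

Measured compounds in an assay on isolated protein for inhibition of ubiquitin carboxyl-terminal hydrolase 7 (Homo sapiens), with stated times of 30 min and 2 h; a lower number here means a stronger inhibitor, a higher number a weaker inhibitor:
compound 1 `Cn1nc2c(=O)n(CC3(O)CCN(Cc4ccc(-c5cnco5)cc4Cl)CC3)cnc2c1-c1ccc(CN)cc1` gives 71.6 nM
compound 2 `Cn1nc2c(=O)n(CC3(O)CCN(Cc4ccc(-c5ccco5)cc4Cl)CC3)cnc2c1-c1ccc(Cl)cc1` gives 143 nM
compound 3 `Cn1nc2c(=O)n(CC3(O)CCN(Cc4ccc(-c5ncco5)cc4Cl)CC3)cnc2c1-c1ccc(CN)cc1` gives 1120 nM

Compound 2 stands second highest of the three numbers in this assay. Its nearest neighbour is compound 1, whose number is lower but within the scatter; its furthest is compound 3, whose number is higher and beyond the scatter.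

Going by the values given here, the only step between compounds differing in one place is a 16-fold higher number from compound 1 to compound 3 (1.19 log units; beyond the scatter), and that concerns the oxazole attachment, not the position changed here.

Compound 4 `Cn1nc2c(=O)n(CC3(O)CCN(Cc4ccc(-c5ccco5)cc4Cl)CC3)cnc2c1-c1ccc(C(=N)N)cc1` differs from compound 2 by a group of 3 heavy atoms (1 carbon, 2 nitrogen; no ring) in place of one chlorine atom, on an aromatic carbon. Among the compounds with values here, no measured step bears directly on this change. Compound 1 and compound 2 differ in two places, one of them at this same aromatic carbon, where compound 1 carries an aminomethyl group; their two values lie within the scatter of each other, so a group with hydrogen-bond donors at this carbon is compatible with a number near that of compound 2.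

Compound 4 is therefore expected to show a step of a 1.4-fold lower number from compound 2 to compound 4 (0.16 log units; within the scatter), not beyond the scatter. The estimate for compound 4 in this assay is 100 nM, with a range from 35 nM to 300 nM.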

Compound 4, half-maximal inhibitory concentration: 87.5 nM
Estimate against measurement, compound 4: 1.1-fold (0.06 log units) above; low and high end bracket the measured number.
By their numbers in this assay, from the lowest: compounds 1, 4 and 2 (each within the scatter of the next); then compound 3.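

In this assay, putting the group of 3 heavy atoms (1 carbon, 2 nitrogen; no ring) in place of chloro on this aromatic carbon, para to a large group, gives a 1.6-fold lower number from compound 2 to compound 4 (0.21 log units; within the scatter). Going by these compounds alone, this is the only reading at this position with the rest of the molecule unchanged. Here, the position accepts a group with 2 hydrogen-bond donors and 1 hydrogen-bond acceptor in place of one with 0 hydrogen-bond donors and 0 hydrogen-bond acceptors, with no step beyond the scatter. Nothing on hand accounts for this result.

As far as these compounds go, whether a carboxylic acid or a nitrile at this carbon would also stay within the scatter of chloro remains open. Also open, from the compounds shown here alone, is whether the same exchange would give a similar step with 1,3-oxazol-5-yl in the rest of the molecule.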